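Swapping Fluoro for Ethoxy on a Shared Core

The compounds below may be only part of what the source reports. "The series", "measured", "known", "first", "only" and "open" are said of these compounds alone.

Of the compounds shown here, two with a common core have been measured. Compound 1 `O=C(N/N=C/c1ccc(F)cc1)c1cnccn1` carries a fluoro group on an aromatic carbon of a six-membered aromatic ring of carbon only. In an ADME assay on J774 cells (Mus musculus) for cytotoxicity, read by MTT assay, with a stated time of 48 h, tested at 150 ug/mL (a higher number here means a weaker effect of the compound at the concentration tested, a lower number a stronger effect), compound 1 gives 71%. Compound 2 `CCOc1cccc(/C=N/NC(=O)c2cnccn2)c1` carries an ethoxy group instead and gives in this assay 69%. The number for compound 1 is the larger of the two, but the gap to compound 2 lies within the usual scatter of repeated measurements, so the two compounds cannot be told apart on these data.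

Compound 3 `CCOc1ccc(/C=N/NC(=O)c2cnccn2)cc1` has not yet been measured. Relative to compound 1 its change is ethoxy in place of fluoro on an aromatic carbon. Going by the values given here, no two measured compounds differ in a single place, so no step size can be read directly from the data. Among the compounds with values here, the only guide is that compound 2, which also carries an ethoxy group, gives 69%, a number close to that of compound 1. The step of a number 3 percentage points lower from compound 1 to compound 3 (within the scatter) is therefore expected to be small, not beyond the scatter. For compound 3 the expected value in this assay is 68%, with a likely range from 52% to 82%.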

Compound 3, a percentage reported as activity, at one concentration (the size of the read-out at that concentration, not a potency): 100%
Compound 3: the middle estimate sits 32 percentage points below what was measured, and the stated range ends below it.
By their numbers in this assay, from the lowest: compounds 2 and 1 (each within the scatter of the next); then compound 3.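

In this assay, ethoxy in place of fluoro on an aromatic carbon, para to a large group, gives a number 29 percentage points higher from compound 1 to compound 3 (beyond the scatter), so at this position the swap clearly weakens the effect of the compound at the concentration tested. Simply carrying an ethoxy group does not settle the number, since compound 2 also has one, at a different place on the ring, and compound 2 gives 69%, while compound 3 gives 100%. No measurement shown here explains why the step at this position has this size.

As far as these compounds go, it remains open whether the jump belongs to ethoxy in particular or would also appear with a methoxy group, a longer chain such as butoxy, or an amine at the same place. Each of these would show how much the number depends on the group itself, and the read-out at a single concentration gives no potency for any of the compounds, so how far they truly differ also stays unsettled.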